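This account rests on a few compounds, and the source may have more. Where it says the series, first, only, none or still open, it means among the compounds named here.

Measured compounds:

Compound 1, `COc1ccc(-n2c(CCc3ccccc3)nnc2[C@H](NC(=O)c2ccccn2)c2c[nH]c3ccccc23)c(OC)c1`, gives 33 nM in an in vitro assay on LLC-PK1 cells for displacement of a labelled ligand from growth hormone secretagogue receptor type 1 (Homo sapiens); a higher number here means a weaker inhibitor, a lower number a stronger inhibitor.
Compound 2, `CCc1ccc(-n2c(CCc3c[nH]c4ccccc34)nnc2[C@H](NC(=O)c2ccccn2)c2c[nH]c3ccccc23)cc1`, gives 49 nM in this assay.
Compound 3, `COc1ccc(-n2c(CCc3ccccc3)nnc2[C@H](NC(=O)Cc2ccccn2)c2c[nH]c3ccccc23)c(OC)c1`, gives 120 nM in this assay.

Compounds 1 and 3 share a core and differ in one place: (pyridin-2-yl)methyl in place of pyridin-2-yl on a carbonyl carbon. This change gave a 3.6-fold higher number from compound 1 to compound 3 (0.56 log units; beyond the scatter), a loss in binding that lies beyond the usual scatter. Compound 2 carries a different core from compound 1; the difference between the two cores is not broken down here. Compound 2 and compound 1 sit close together in this assay, within the scatter of each other, so no order between them can be read from these two values.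

Compound 4, `CCc1ccc(-n2c(CCc3c[nH]c4ccccc34)nnc2[C@H](NC(=O)Cc2ccccn2)c2c[nH]c3ccccc23)cc1`, is not yet measured. It differs from compound 2 in one place: (pyridin-2-yl)methyl in place of pyridin-2-yl on a carbonyl carbon. This is the same change as the one from compound 1 to compound 3, made on the same kind of carbonyl carbon with an amide-type nitrogen as its other neighbour, and it occurs twice among the compounds shown. For the measured compounds named here, only one measured instance of this change exists, so how far it carries across to the core of compound 2 is not established.

Going by the values given here, the expectation for compound 4 rests on compound 2 at 49 nM and on the size of the measured step of a 3.6-fold higher number from compound 1 to compound 3 (0.56 log units; beyond the scatter), which is the only step of this kind available and is taken as the best guide. On that basis a step of about a 3.5-fold higher number from compound 2 to compound 4 (0.54 log units; beyond the scatter) is expected from compound 2 to compound 4, a loss of similar size to the earlier one. Among the compounds with values here, compound 4 is therefore estimated at 170 nM in this assay, with a range from 70 nM to 450 nM that allows for the single precedent and the ordinary scatter.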

Compound 4, half-maximal inhibitory concentration: 96 nM
Estimate against measurement, compound 4: 1.8-fold (0.25 log units) above; measured number inside the range.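

In this assay, (pyridin-2-yl)methyl in place of pyridin-2-yl on the carbonyl carbon gave a 2.0-fold higher number from compound 2 to compound 4 (0.29 log units; within the scatter), so on the core of compound 2 this step alone does not clear the usual scatter. Set beside the earlier step, the size of the change does not separate between the two cores: the same change on two cores in this assay, a 3.6-fold higher number (0.56 log units; beyond the scatter) from compound 1 to compound 3 and a 2.0-fold higher number (0.29 log units; within the scatter) from compound 2 to compound 4, 1.9-fold (0.27 log units) apart, within the scatter of two such steps. For the compounds shown here, the two steps therefore give no sign that the core alters the effect of this change, and both run towards a higher number, but only the step on the core of compound 1 stands as a loss beyond the scatter, and two cores cannot establish a constant step size or show that it holds on any other core.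

The compounds shown leave open how binding responds on the same carbonyl carbon to a longer chain ending in pyridin-2-yl, or to a group carrying an amine or a carboxylic acid in place of the pyridin-2-yl ring. They also do not separate the contributions of the several places in which the core of compound 1 and the core of compound 2 differ.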